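Isobutyl in Place of Isopropyl, from Compound 3 to Compound 4

The compounds below may be only part of what the source reports. "The series", "measured", "known", "first", "only" and "open" are said of these compounds alone.

Compound 1 `C=CCONC(=O)Cn1cc(C(=O)N[C@@H](C)C(=O)N[C@@H](CC(C)C)C(=O)O)c2ccccc21`, compound 2 `CC(C)C[C@H](NC(=O)CNC(=O)c1cn(CC(=O)NOCc2ccccc2)c2ccccc12)C(=O)O` and compound 3 `CC(C)[C@H](NC(=O)[C@H](C)NC(=O)c1cn(CC(=O)NOCc2ccccc2)c2ccccc12)C(=O)O` share one core and were all tested in a functional assay on MRC5 cells (Homo sapiens) for inhibition, read by microscopy and resazurin assay, with a stated time of 72 h; on this read-out lower numbers stand for stronger inhibition and higher numbers for weaker inhibition. Compound 1 reaches only the limit of > 128000 nM in this assay. Compound 2 likewise gives only the limit of > 128000 nM. Compound 3 also stops at the limit of > 128000 nM. Among the measured compounds shown here, compound 3 therefore stands nowhere that a number could place it: every value so far is a limit, as the limit of > 128000 nM in this assay, at which 3 of the 3 values shown sit, records. For the measured compounds named here, the single step between measured compounds, a step that the two limits leave unreadable from compound 2 to compound 3, joins two limits and its size cannot be read.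

Compound 4 `CC(C)C[C@H](NC(=O)[C@H](C)NC(=O)c1cn(CC(=O)NOCc2ccccc2)c2ccccc12)C(=O)O` differs from compound 3 by isobutyl in place of isopropyl on a saturated chain carbon bound to an amide-type nitrogen and a carbonyl carbon. Going by the values given here, no measured step bears on this change with a readable size, since the one comparable step between measured compounds is itself bounded by limits at both ends. With every member of the set at the limit of this assay, there is no basis for expecting a step beyond the scatter in either direction. Compound 4 is accordingly estimated at 128000 nM, with a range from 64000 nM to 128000 nM. This estimate implies a number no higher from compound 3 to compound 4 (the limit leaves the size open), and the result for compound 4 is expected most likely to be reported again only as a limit.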

Compound 4, half-maximal inhibitory concentration: > 128000 nM
Compound 4 ended at the assay's limit (the forecaster's own chance of this, stated with the estimate: 85%); the middle value lies on the limit itself.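

In this assay compound 4 gives > 128000 nM, which is a limit and not a number. No step from compound 1, compound 2 or compound 3 to compound 4 can be read, because all four compounds stop at a limit: the limit of > 128000 nM in this assay, at which 4 of the 4 values shown sit.

The compounds shown leave open what number any of them would reach in this assay, and so whether isobutyl in place of isopropyl changes anything.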